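From cyclopentyl to neopentyl on a shared core

The compounds below may be only part of what the source reports. "The series", "measured", "known", "first", "only" and "open" are said of these compounds alone.

Compound 1 `CC(C)COc1cc(C(F)(F)F)nn1-c1ccc(S(C)(=O)=O)cn1` gives 50 ug/mL
Compound 2 `CC(C)COc1cc(C(F)(F)F)nn1-c1ccc(S(C)(=O)=O)cc1` gives "not determined" (no result reported)
Compound 3 `CS(=O)(=O)c1ccc(-n2nc(C(F)(F)F)cc2OC2CCCC2)cc1` gives 25 ug/mL

Within the data shown here, these results come from a physicochemical assay for solubility (a higher number here means a more soluble compound, a lower number a less soluble compound), and only two of them are numbers. Compound 3 at 25 ug/mL lies within the usual scatter of compound 1 at 50 ug/mL so the two cannot be told apart, and compound 2 offers nothing to set beside them.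

Compound 4 `CC(C)(C)COc1cc(C(F)(F)F)nn1-c1ccc(S(C)(=O)=O)cc1` has not been measured yet. It differs from compound 3 in one place, and the change reads neopentyl in place of cyclopentyl on an oxygen on an aromatic ring. Among the measured compounds shown here, no two measured compounds differ in one place only, so the data hold no direct precedent for this swap. For the measured compounds named here, the best anchor is compound 3 at 25 ug/mL and nothing measured so far points in either direction. The expected size of the change is no change at the digits printed from compound 3 to compound 4 (within the scatter) and that is no step beyond the scatter. For compound 4 the estimate is 25 ug/mL with an expected range from 10 ug/mL to 60 ug/mL once it is measured.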

Compound 4, solubility: 50 ug/mL
Compound 4: the middle estimate sits 2.0-fold (0.30 log units) below what was measured; low and high end bracket the measured number.
By their numbers in this assay, from the lowest: compounds 3, 1 and 4 (each within the scatter of the next).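

The pair of compound 3 and compound 4 is the first among these compounds to differ in one place only, so this position on the shared core now has a direct reading. In this assay, putting neopentyl in place of cyclopentyl on an oxygen on an aromatic ring gives a 2.0-fold higher number from compound 3 to compound 4 (0.30 log units; within the scatter) and so opening the five-membered ring into an open group of the same heavy-atom count leaves a result that cannot be told apart from the ring. No measurement here bears on why the two groups read alike.

One pair cannot show how far this holds for other groups on that oxygen, such as a longer chain, a chain ending in an amine or one ending in a carboxylic acid. It also leaves open whether the same swap would read alike on the core of compound 1.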